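A Methyl on the Benzyl Amide Carbon

The compounds below may be only part of what the source reports. "The series", "measured", "known", "first", "only" and "open" are said of these compounds alone.

Compound 1 `CCCCc1oc2ccccc2c1C(=O)c1ccc(OCC(=O)N2CCOCC2)cc1`: 34000 nM
Compound 2 `CCCCc1oc2ccccc2c1C(=O)c1ccc(OCC(=O)NCc2ccccc2)cc1`: 19600 nM

Within the data shown here, in a functional assay on MCF7 cells (Homo sapiens) for antiproliferative activity, read by MTT assay, with a stated time of 24 h (on this read-out lower numbers stand for stronger inhibition and higher numbers for weaker inhibition), compound 2 gives 19600 nM, which lies within the scatter of compound 1, the only other compound measured. Compound 3 `CCCCc1oc2ccccc2c1C(=O)c1ccc(OCC(=O)N[C@@H](C)c2ccccc2)cc1` carries one change from compound 2: methyl in place of hydrogen on a saturated chain carbon bound to an amide-type nitrogen and an aromatic carbon. This is methyl in place of hydrogen on a saturated chain carbon bound to an amide-type nitrogen and an aromatic carbon. Among the measured compounds shown here, the only measured step, a 1.7-fold lower number from compound 1 to compound 2 (0.24 log units; within the scatter), stayed within the scatter, and it concerns a different replacement. For the measured compounds named here, no measured step tests this methyl, so no change beyond the scatter is expected in this assay. The expected step is a 1.1-fold lower number from compound 2 to compound 3 (0.04 log units; within the scatter). Compound 3 is estimated at 18000 nM, with an expected range of 8000 nM to 40000 nM.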

Compound 3, half-maximal inhibitory concentration: 17900 nM
For compound 3 the middle estimate is 1.0-fold (0.00 log units) above the measured one; the measured number falls inside the stated range.
By their numbers in this assay, from the lowest: compounds 3, 2 and 1 (each within the scatter of the next).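

In this assay methyl in place of hydrogen on the saturated chain carbon gives a 1.1-fold lower number from compound 2 to compound 3 (0.04 log units; within the scatter) and so leaves compound 3 within the scatter of compound 2. The (1-phenylethyl)amino group in place of morpholin-4-yl gives a 1.9-fold lower number from compound 1 to compound 3 (0.28 log units; within the scatter) and also stays within the scatter, so this methyl opens no gap from compound 1. No further data bear on this result. The compounds shown leave open whether an ethyl or a hydroxymethyl on this carbon, or the mirror-image 1-phenylethyl group, would give a step beyond the scatter.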